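A Smaller Amine on the Aromatic Ring: Expected Cytotoxicity

The source may hold more compounds than are shown below. What is called first, only, known or untested is meant among the compounds shown, and "the series" means these compounds.

Compound 1 `OCc1cc(N2CCCC2)ccc1-c1nc2c(s1)C(O)CCC2`: 21000 nM
Compound 2 `CN(C)c1ccc(-c2nc3c(s2)C(O)CNC3)c(CO)c1`: > 100000 nM
Compound 3 `OCc1cc(N2CCCC2)ccc1-c1nc2c(s1)C(O)CNC2`: > 100000 nM

Among the compounds with values here, in a functional assay on HCT-116 cells (Homo sapiens) for cytotoxicity, read by sulforhodamine B assay, with a stated time of 2 days (a higher number here means a weaker inhibitor, a lower number a stronger inhibitor), compound 1 gives 21000 nM, the only real number among the three. For compound 2 the value > 100000 nM is a limit of the assay, not a number. For compound 3 the value > 100000 nM is likewise a limit. Compound 3 and compound 2 differ by one change, (dimethylamino in place of pyrrolidin-1-yl on an aromatic carbon), and the step that the two limits leave unreadable from compound 3 to compound 2 cannot be read because of the limit of > 100000 nM in this assay, at which 2 of the 3 values shown sit. Compound 1 and compound 3 differ in their cores, a difference not broken down here. Compound 4, `CN(C)c1ccc(-c2nc3c(s2)C(O)CCC3)c(CO)c1`, is not yet measured; it differs from compound 1 by dimethylamino in place of pyrrolidin-1-yl on an aromatic carbon, the same change. Within the data shown here, since the only measured example of this change is unreadable, the expected step of a 1.4-fold higher number from compound 1 to compound 4 (0.15 log units; within the scatter) rests on the value of compound 1 alone, 21000 nM. Compound 4 is therefore expected to land at about 30000 nM, estimated between 10000 nM and 100000 nM.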

Compound 4, half-maximal inhibitory concentration: 78000 nM
Beside the measured number, compound 4's estimate is 2.6-fold (0.41 log units) below it; measured number inside the range.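

In this assay, dimethylamino in place of pyrrolidin-1-yl gives a 3.7-fold higher number from compound 1 to compound 4 (0.57 log units; beyond the scatter), a modest weakening on the core of compound 1. The same change on the other core, the step from compound 3 to compound 2, cannot be read, because both values are limits of the assay and not numbers: the limit of > 100000 nM in this assay, at which 2 of the 4 values shown sit. So there is one readable example of this change, on one core, and nothing here shows whether its size carries over to the other core.

As far as these compounds go, whether a piperidine or a morpholine at the same place would give a number nearer to compound 1 or to compound 4 stays open. Also open, from the compounds shown here alone, is how the change would behave on the core of compound 3 in a pair with readable numbers.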